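Replacing dimethylamino with methylsulfanyl in compound 4

A few compounds are considered here, and "the series" means these few. Any claim that something is new, unique, unknown or untested is made for them only; others in the source may bear on it.

Measured in a functional assay on DU-145 cells (Homo sapiens) for inhibition, read by trypan blue exclusion, with a stated time of 96 h; a lower number here means a stronger inhibitor of growth, a higher number a weaker inhibitor of growth:
- compound 1 `CSc1ccc(/C=C(/SCc2ccc(C)cc2)C(=O)c2ccc(Cl)cc2)cc1`: 25000 nM
- compound 2 `Cc1ccc(/C=C(/SCc2ccc(Cl)cc2)C(=O)c2ccc(Cl)cc2)s1`: 50000 nM
- compound 3 `CN(C)c1ccc(/C=C(/SCc2ccc(Cl)cc2)C(=O)c2ccc(Cl)cc2)cc1`: > 100000 nM, a limit of the assay

Compound 3 has no number on this read-out, only the limit > 100000 nM. The next compound is compound 4 `CSc1ccc(/C=C(/SCc2ccc(Cl)cc2)C(=O)c2ccc(Cl)cc2)cc1`, which carries methylsulfanyl in place of dimethylamino on an aromatic carbon, para to a large group: methylsulfanyl in place of dimethylamino on an aromatic carbon. Among the measured compounds shown here, the one measured step that bears directly on this change is an at least 2.0-fold higher number from compound 2 to compound 3 (0.30 log units; that floor lies within the scatter). As it rests on a limit, it gives no true size. The 4-(methylsulfanyl)phenyl of compound 4 also stands in compound 1, which gives 25000 nM, although the two differ elsewhere. A number close to that one is therefore expected in this assay, on the side of stronger growth inhibition. The estimated change is an at least 3.3-fold lower number from compound 3 to compound 4 (0.52 log units; beyond the scatter). For compound 4 the estimated value is 30000 nM, with an expected range from 10000 nM to 90000 nM.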

Compound 4, concentration for 50% growth inhibition: 25000 nM
Compound 4: middle estimate off by 1.2-fold (0.08 log units), on the high side; measured number inside the range.
By their numbers in this assay, from the lowest: compounds 1, 4 and 2 (each within the scatter of the next). At a limit, above all of these: compound 3.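

In this assay, methylsulfanyl in place of dimethylamino on an aromatic carbon, para to a large group, gives an at least 4.0-fold lower number from compound 3 to compound 4 (0.60 log units; beyond the scatter), so a change at this position now clears the scatter. The other two new steps stay small: 4-(methylsulfanyl)phenyl in place of 5-methylthiophen-2-yl gives a 2.0-fold lower number from compound 2 to compound 4 (0.30 log units; within the scatter), and chloro in place of methyl on an aromatic carbon gives no change at the digits printed from compound 1 to compound 4 (within the scatter). The full size of the first step cannot be read because compound 3 stands only at a limit of the assay: the limit of > 100000 nM in this assay, at which 1 of the 4 values shown sits.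

The compounds shown leave open how this assay would read with methoxy, a primary amine or a carboxylic acid at this position. They also leave open what a longer chain on the sulfur would give.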